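Swapping a Sulfonamide for an Amide: Expected Monkey Exposure

A few compounds are considered here, and "the series" means these few. Any claim that something is new, unique, unknown or untested is made for them only; others in the source may bear on it.

Compound 1 `CCCCN(c1nc2c(NS(C)(=O)=O)cccc2o1)[C@H](C)c1ccc(-c2ccccc2-c2nnn[nH]2)cc1`: 49.9 nM in an ADME assay on the whole organism (Macaca fascicularis) for pharmacokinetics, read by LC-MS, using cassette dosing, at a dose of 1 mg/kg by the oral route; a lower number here means less compound in the circulation, a higher number more compound in the circulation at the dose given
Compound 2 `Cc1ccc(-c2nc(=O)o[nH]2)c(-c2ccc([C@@H](C)N(CC3CC3)c3nc4c(C(=O)O)cccc4o3)cc2)c1`: 2920 nM in this assay

Compound 1 stands lowest of the two numbers measured here; compound 2 gives 2920 nM, a gap beyond the scatter. Compound 3 `CCCCN(c1nc2c(C(=O)N(C)C)cccc2o1)[C@H](C)c1ccc(-c2ccccc2-c2nnn[nH]2)cc1` differs from compound 1 by dimethylcarbamoyl in place of methanesulfonamido on an aromatic carbon. Going by the values given here, no step between measured compounds bears on this change, so any expectation rests on compound 1 alone. Compound 3 is expected to give a modestly higher number in this assay, a 2.0-fold higher number from compound 1 to compound 3 (0.30 log units; within the scatter), though a result within the scatter would not surprise. Compound 3 is therefore estimated at 100 nM, with a range from 25 nM to 400 nM.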

Compound 3, maximal plasma concentration: 54 nM
Estimate against measurement, compound 3: 1.9-fold (0.27 log units) above, within the range that was stated.
By their numbers in this assay, from the lowest: compounds 1 and 3 (each within the scatter of the next); then compound 2.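

In this assay, dimethylcarbamoyl in place of methanesulfonamido on this aromatic carbon gives a 1.1-fold higher number from compound 1 to compound 3 (0.03 log units; within the scatter), so on the core of compound 1 the two groups cannot be told apart by maximal plasma concentration. This holds even though the hydrogen-bond donor of methanesulfonamido is gone from compound 3. Nothing measured here offers an explanation for this result. Going by these compounds, whether a nitrile or an amine on the same carbon would also stay within the scatter remains open. So does whether this step would hold on any other core.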